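A few compounds are considered here, and "the series" means these few. Any claim that something is new, unique, unknown or untested is made for them only; others in the source may bear on it.

Values in an assay on CHO cells for displacement of a labelled ligand from 5-hydroxytryptamine receptor 1D (Homo sapiens); a higher number here means a weaker inhibitor, a lower number a stronger inhibitor:

compound 1, `c1ccc2c(c1)CCC2NC1CCN(CCCc2c[nH]c3ccc(-n4cnnc4)cc23)CC1`: 8.9 nM
compound 2, `c1ccc(CNC2CCN(CCCc3c[nH]c4ccc(-n5cnnc5)cc34)CC2)cc1`: 4.6 nM
compound 3, `CN(Cc1ccsc1)C1CCN(CCCc2c[nH]c3ccc(-n4cnnc4)cc23)CC1`: 1.5 nM

Compound 3 gives the lowest number of the three and is the strongest inhibitor here: the steps of a 5.9-fold lower number from compound 1 to compound 3 (0.77 log units; beyond the scatter) and a 3.1-fold lower number from compound 2 to compound 3 (0.49 log units; beyond the scatter) both lie beyond the scatter, while a 1.9-fold lower number from compound 1 to compound 2 (0.29 log units; within the scatter) lies within it.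

Compound 4, `C[C@H](NCC1CCN(CCCc2c[nH]c3ccc(-n4cnnc4)cc23)CC1)c1ccccc1`, has not yet been measured in this assay. It differs from compound 3 in one place: ((1-phenylethyl)amino)methyl in place of methyl((thiophen-3-yl)methyl)amino on a saturated ring carbon. The step that bears most directly on it is a 3.1-fold lower number from compound 2 to compound 3 (0.49 log units; beyond the scatter), in which a benzylamino group on the same saturated ring carbon gave a modestly higher number than the methyl((thiophen-3-yl)methyl)amino group; the step of a 5.9-fold lower number from compound 1 to compound 3 (0.77 log units; beyond the scatter) points the same way. For the measured compounds named here, compound 4 returns to a secondary amine bearing a six-membered aromatic ring of carbon only, with a methylene spacer and a defined stereocentre that none of the measured compounds carry, so the size of any shift is uncertain. A modest move back toward a higher number is expected, of about a 2.7-fold higher number from compound 3 to compound 4 (0.43 log units; beyond the scatter). Compound 4 is therefore estimated at 4 nM in this assay, within a range of 1.5 nM to 12 nM.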

Compound 4, half-maximal inhibitory concentration: 4.4 nM
Compound 4: the middle estimate sits 1.1-fold (0.04 log units) below what was measured, within the range that was stated.
By their numbers in this assay, from the lowest: compound 3; then compounds 4, 2 and 1 (each within the scatter of the next, the first and the last beyond it).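

In this assay, ((1-phenylethyl)amino)methyl on the saturated ring carbon three ring bonds from the ring nitrogen stands level with benzylamino, at a 1.0-fold lower number from compound 2 to compound 4 (0.02 log units; within the scatter), even though the amine, the spacer and the new stereocentre all differ. For the compounds shown here, the step of a 2.9-fold higher number from compound 3 to compound 4 (0.47 log units; beyond the scatter) leaves compound 3 as the only compound beyond the scatter from all the others, while a 2.0-fold lower number from compound 1 to compound 4 (0.31 log units; beyond the scatter) lies only just beyond the scatter. No measurement is available that explains these differences.

The step to compound 4 changes the thiophen-3-yl ring, the methyl on the amine nitrogen and the place of that nitrogen together, so the gap to compound 3 cannot be assigned to any one of them. A methyl(benzyl)amino group would bear on the ring and the methyl, and the mirror-image 1-phenylethyl group on the stereocentre, but the compounds shown settle neither point.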